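Swapping the furan end of compound 2

A few compounds are considered here, and "the series" means these few. Any claim that something is new, unique, unknown or untested is made for them only; others in the source may bear on it.

Compound 2 `c1ccc(-c2ccc3c(NCCCNCc4ccco4)ccnc3c2)cc1` gives 32000 nM in a physicochemical assay for solubility, with a stated time of 18 h, at pH 7.4 (a lower number here means a less soluble compound, a higher number a more soluble compound), the highest of the three numbers; compound 1 `CC(C)Cc1ccc2c(NCCCNCc3ccco3)ccnc2c1` gives 4200 nM and compound 3 `CC(C)CCc1ccc2c(NCCCNCc3ccco3)ccnc2c1` gives 4200 nM. The steps of a 7.6-fold higher number from compound 1 to compound 2 (0.88 log units; beyond the scatter) and a 7.6-fold lower number from compound 2 to compound 3 (0.88 log units; beyond the scatter) both concern the group on the aromatic carbon, while no change at the digits printed from compound 1 to compound 3 (within the scatter) concerns only the saturated chain there. Compound 4 `COc1cccc(CNCCCNc2ccnc3cc(-c4ccccc4)ccc23)c1O` differs at the other end: 2-hydroxy-3-methoxyphenyl in place of furan-2-yl on a saturated chain carbon bound to an amine nitrogen. Going by the values given here, no measured step touches this place, so the three steps give no direct guide to its size or direction. With the phenyl on the aromatic carbon kept, compound 4 is expected to land near its parent, at an estimated 20000 nM, ranging from 5000 nM to 80000 nM. The expected step is a 1.6-fold lower number from compound 2 to compound 4 (0.20 log units; within the scatter).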

Compound 4, solubility: 32000 nM
The estimate for compound 4 lay 1.6-fold (0.20 log units) below the measured number; the range from low to high includes it.
By their numbers in this assay, from the lowest: compounds 1 and 3 (each within the scatter of the next); then compounds 2 and 4 (each within the scatter of the next).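

Going by these compounds alone, at this place, on a saturated chain carbon bound to an amine nitrogen, the single measured step is no change at the digits printed from compound 2 to compound 4 (within the scatter) in this assay. With the phenyl on the aromatic carbon kept, furan-2-yl with 5 heavy atoms and no hydrogen-bond donor thus gives way to 2-hydroxy-3-methoxyphenyl with 9 heavy atoms and 1 hydrogen-bond donor, and the step stays within the scatter. Nothing available explains this result.

From the compounds shown here alone, whether the same swap behaves alike with isobutyl or isopentyl on the aromatic carbon remains open. So does the effect of a pyridine ring or a carboxylic acid at this place.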